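Replacing the substituted phenyl group of compound 3

The compounds below may be only part of what the source reports. "The series", "measured", "known", "first", "only" and "open" are said of these compounds alone.

In a functional assay on A549 cells (Homo sapiens) for antiproliferative activity, read by MTT assay, with a stated time of 72 h (on this read-out lower numbers stand for stronger inhibition and higher numbers for weaker inhibition), compound 1 `CN1CCN(Cc2ccc(NC(=O)Nc3ccc4ncnc(Nc5ccc(F)c(Cl)c5)c4c3)cc2)CC1` gives 3480 nM. Compound 3 `COc1ccc(Nc2ncnc3ccc(NC(=O)Nc4ccc(CN5CCN(C)CC5)cc4)cc23)cc1Cl` gives 3570 nM. That is a 1.0-fold higher number from compound 1 to compound 3 (0.01 log units; within the scatter), within the scatter, so these two stand level, and this step also shows that methoxy in place of fluoro on an aromatic carbon left the number unmoved. Compound 2 `CN1CCN(Cc2ccc(NC(=O)Nc3ccc4ncnc(Nc5ccc(F)c(F)c5)c4c3)cc2)CC1` reports only a limit, > 10000 nM.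

Compound 4 `COC(=O)c1cccc(Nc2ncnc3ccc(NC(=O)Nc4ccc(CN5CCN(C)CC5)cc4)cc23)c1` has not yet been measured. It differs from compound 3 in one place, on a nitrogen on an aromatic ring: 3-(methoxycarbonyl)phenyl in place of 3-chloro-4-methoxyphenyl on a nitrogen on an aromatic ring. In short, 3-(methoxycarbonyl)phenyl takes the place of 3-chloro-4-methoxyphenyl.

The other steps concern the same group. Fluoro in place of chloro gave an at least 2.8-fold higher number from compound 1 to compound 2 (0.45 log units; beyond the scatter), beyond the scatter. The reverse kind of change gave an at least 2.8-fold lower number from compound 2 to compound 3 (0.44 log units; beyond the scatter), also beyond the scatter. Among these three compounds, the two that carry chloro give numbers, and none goes against this. Going by the values given here, compound 4 has no chloro, and its entering group has no measured precedent here. A modest rise is therefore expected, a 2.0-fold higher number from compound 3 to compound 4 (0.29 log units; within the scatter), though the range stays wide and a limit is possible. The estimate for compound 4 is 7000 nM, with an expected range of 2500 nM to 20000 nM.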

Compound 4, half-maximal inhibitory concentration: > 10000 nM
Compound 4: only a limit was reported (the forecaster's own chance of this, stated with the estimate: 35%); at least 1.4-fold (0.15 log units) between middle value and limit.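

In this assay, 3-(methoxycarbonyl)phenyl on the nitrogen does not hold the level of the two compounds that carry chloro, giving an at least 2.8-fold higher number from compound 3 to compound 4 (0.44 log units; beyond the scatter) and an at least 2.8-fold higher number from compound 1 to compound 4 (0.45 log units; beyond the scatter). The earlier compounds shown here showed such a step only for the exchange of one halogen on the ring, whereas here a different group altogether, with no halogen, ends in the same place, and the pattern now covers all four compounds: the two with chloro give numbers, the two without give limits, and none goes against this. Both steps are minimum sizes, and the step between compound 2 and compound 4 cannot be read, since both compounds give only a limit, the same one: the limit of > 10000 nM in this assay, at which 2 of the 4 values shown sit.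

Compound 4 loses chloro and methoxy and gains methoxycarbonyl in a single change, so the compounds shown cannot tell whether the missing chloro or the entering group accounts for the step. Also open, going by these compounds, is whether a carboxylic acid or a primary amide in place of methoxycarbonyl, or a phenyl carrying chloro alone, would give a number or another limit.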